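Pyridin-2-yl in place of 2-fluorophenyl

A few compounds are considered here, and "the series" means these few. Any claim that something is new, unique, unknown or untested is made for them only; others in the source may bear on it.

Compound 1 (`CN(C)c1ccc2cc(-c3ccccc3F)c(N)nc2c1`) has little measured behind it in an ADME assay on microsomes from liver (Mus musculus) for metabolic stability, read by HPLC, with a stated time of 4 h; a lower number here means that the compound disappears faster, a higher number that the compound lasts longer. In this assay compound 1 gives < 0.1 h, which is a limit of the assay and not a number. Compound 2 (`CN(C)c1ccc2cc(-c3cc(Cl)ccc3Cl)c(N)nc2c1`) likewise gives only a limit, < 0.1 h. For the measured compounds named here, compound 3 (`CN(C)c1ccc2cc(-c3cc(Cl)cc(Cl)c3)c(N)nc2c1`) gives 0.17 h, the only true number among the three. Compound 1 therefore stands at the limit of < 0.1 h in this assay, at which 2 of the 3 values shown sit, and has no exact half-life to serve as a starting point.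

Compound 4 (`CN(C)c1ccc2cc(-c3ccccn3)c(N)nc2c1`) keeps the core of compound 1 but carries pyridin-2-yl in place of 2-fluorophenyl on an aromatic carbon. Going by the values given here, no pair of measured compounds isolates a single change, so the size of this step in this assay can only be estimated. The expectation rests on compound 3 at 0.17 h, which shows a short half-life on the shared core. Only a small rise in half-life is expected, and the estimated change is an at least 1.2-fold higher number from compound 1 to compound 4 (0.07 log units; that floor lies within the scatter). The assay may well report only a limit again. For compound 4 the expected half-life is 0.12 h, within an estimated range of 0.05 h to 0.3 h.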

Compound 4, half-life: < 0.1 h
Compound 4: a limit, no number; the forecaster's own chance of this, stated with the estimate: 45%; middle value at least 1.2-fold (0.07 log units) from the limit.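

In this assay compound 4 gives < 0.1 h, which is a limit of the assay and not a number. For the compounds shown here, compound 1 also gives only a limit, so no step between compound 1 and compound 4 can be read. The compounds shown leave open how the half-life differs between pyridin-2-yl and 2-fluorophenyl on the shared core.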